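The compounds below may be only part of what the source reports. "The series", "measured", "known", "first", "only" and "open" are said of these compounds alone.

Compound 1 `N/C(=N\NC(=S)N1CCOCC1)c1ccccn1` gives 7300 nM in a functional assay on HeLa cells (Homo sapiens) for cytotoxicity, read by MTT assay, with a stated time of 72 h; a higher number here means a weaker inhibitor, a lower number a stronger inhibitor.
Compound 2 `N/C(=N\NC(=S)N1CCCCC1)c1ccccn1` gives 3800 nM in this assay.
Compound 3 `Cc1cccc(/C(N)=N/NC(=S)N2CCOCC2)n1` gives 2200 nM in this assay.

Compound 2 differs from compound 1 by piperidin-1-yl in place of morpholin-4-yl on a thiocarbonyl carbon and the step this made is a 1.9-fold lower number from compound 1 to compound 2 (0.28 log units; within the scatter). Compound 3 differs from compound 1 by methyl in place of hydrogen on an aromatic carbon and here the step is a 3.3-fold lower number from compound 1 to compound 3 (0.52 log units; beyond the scatter). The numbers for compound 2 and compound 3 sit close to one another, so between them nothing more can be said.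

Compound 4 `Cc1cccc(/C(N)=N/NC(=S)N2CCCCC2)n1` has not yet been measured in this assay. It differs from compound 3 by piperidin-1-yl in place of morpholin-4-yl on a thiocarbonyl carbon, the same change that separates compound 2 from compound 1, made at a place described in the same words in both pairs. Within the data shown here, the one earlier example of this change, a 1.9-fold lower number from compound 1 to compound 2 (0.28 log units; within the scatter), stayed within the scatter, so the same kind of small step is expected from compound 3 to compound 4, namely a 1.5-fold lower number from compound 3 to compound 4 (0.17 log units; within the scatter), with little confidence in its direction because a 1.9-fold lower number from compound 1 to compound 2 (0.28 log units; within the scatter) is itself within the scatter. Compound 4 is therefore estimated at 1500 nM in this assay, with a range from 600 nM to 4000 nM.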

Compound 4, half-maximal inhibitory concentration: 2000 nM
Estimate against measurement, compound 4: 1.3-fold (0.12 log units) below, and the stated range covers the measured number.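

In this assay, piperidin-1-yl in place of morpholin-4-yl on a thiocarbonyl carbon gives a 1.1-fold lower number from compound 3 to compound 4 (0.04 log units; within the scatter), and this step agrees with its earlier counterpart: the same change on two cores in this assay, a 1.9-fold lower number (0.28 log units; within the scatter) from compound 1 to compound 2 and a 1.1-fold lower number (0.04 log units; within the scatter) from compound 3 to compound 4, 1.7-fold (0.24 log units) apart, within the scatter of two such steps
Methyl in place of hydrogen on an aromatic carbon gives a 1.9-fold lower number from compound 2 to compound 4 (0.28 log units; within the scatter), and this change also carries across the two cores without a gap that can be told from noise: the same change on two cores in this assay, a 3.3-fold lower number (0.52 log units; beyond the scatter) from compound 1 to compound 3 and a 1.9-fold lower number (0.28 log units; within the scatter) from compound 2 to compound 4, 1.7-fold (0.24 log units) apart, within the scatter of two such steps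
This shows that neither change behaved differently enough on the second core to be detected, but it does not establish a fixed, additive effect: the evidence rests on just two cores, the piperidin-1-yl steps both stay within the scatter, and the methyl step passes beyond the scatter only on the core of compound 1.

The compounds shown leave open whether a piperazin-1-yl ring or an open-chain dimethylamino group on the thiocarbonyl carbon would fit the same picture. They also leave open whether a longer chain such as ethyl, or a chlorine atom, on the aromatic carbon would carry across the cores as methyl does.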